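A few compounds are considered here, and "the series" means these few. Any claim that something is new, unique, unknown or untested is made for them only; others in the source may bear on it.

The measured compounds and their results:
compound 1 `O=C1CN(C2CCCC2)c2nc(Nc3ccc(N4CCCCC4)cc3)ncc2N1`, which in a functional assay on MDA-MB-231 cells (Homo sapiens) for inhibition, read by MTT assay, with a stated time of 48 h (on this read-out higher numbers stand for weaker inhibition and lower numbers for stronger inhibition), gives 25000 nM
compound 2 `CC1CCN(c2ccc(Nc3ncc4c(n3)N(C3CCCC3)CC(=O)N4)cc2)CC1`, which in this assay gives 22700 nM
compound 3 `O=C1CN(C2CCCC2)c2nc(Nc3ccc(N4CCCCC4)cn3)ncc2N1`, for which this assay reports only a limit, > 30000 nM

The two plain numbers differ only by a 1.1-fold lower number from compound 1 to compound 2 (0.04 log units; within the scatter), so compound 1 and compound 2 cannot be ranked against each other. The result for compound 3 is a limit and not a number, a case described by the limit of > 30000 nM in this assay, at which 1 of the 3 values shown sits.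

The next compound, compound 4 `CC1CCN(c2ccc(Nc3ncc4c(n3)N(C3CCCC3)CC(=O)N4C)cc2)CC1`, differs from compound 2 in one spot: methyl in place of hydrogen on an amide-type nitrogen in a ring. For the measured compounds named here, the only measured single-point step, from compound 1 to compound 2, placed a methyl on a saturated ring carbon and stayed within the scatter; it says nothing about a methyl on the amide-type nitrogen of the shared core, and no other pair of measured compounds isolates that change. Going by the values given here, with no step to lean on, the expectation for compound 4 in this assay is no shift beyond the scatter, held with wide uncertainty. Compound 4 is therefore estimated at 28000 nM, with a range from 9000 nM to 90000 nM, which corresponds to an expected step of a 1.2-fold higher number from compound 2 to compound 4 (0.09 log units; within the scatter).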

Compound 4, half-maximal inhibitory concentration: > 30000 nM
Compound 4: no number, only a limit; the forecaster's own chance of this, stated with the estimate: 45%; middle value at least 1.0-fold (0.02 log units) from the limit.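

Placing a methyl on the amide-type nitrogen gives the first view of this position on the shared core, and in this assay compound 4 reports only a limit, > 30000 nM. On these data alone, the change can therefore be read only as a floor, an at least 1.3-fold higher number from compound 2 to compound 4 (0.12 log units; that floor lies within the scatter), so the true size of the step is unknown: it may be small, or it may be much larger. Unlike the earlier step on the saturated ring carbon, which had a plain number at both ends, this step has no upper end, and compound 4 joins compound 3 among the compounds without a number: the limit of > 30000 nM in this assay, at which 2 of the 4 values shown sit.

The compounds shown carry only hydrogen or methyl on this nitrogen, so it remains open how an ethyl group or a longer chain ending in an amine would read there. As far as these compounds go, it also remains open whether the same methyl would give a plain number on the core of compound 1, which lacks the methyl on the saturated ring carbon.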